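Swapping Chloro for Amino: One Change Seen Twice

The source may hold more compounds than are shown below. What is called first, only, known or untested is meant among the compounds shown, and "the series" means these compounds.

Of the compounds shown here, three have been measured in a functional assay on SK-MEL-28 cells (Homo sapiens) for cytotoxicity, read by sulforhodamine B assay, with a stated time of 48 h; a lower number here means a stronger inhibitor of growth, a higher number a weaker inhibitor of growth. Compound 3 `ClCc1ccc(Cn2cnc3c(Cl)nc(Cl)nc32)cc1` gives 6920 nM, compound 2 `ClCc1cccc(Cn2cnc3c(Cl)nc(Cl)nc32)c1` gives 5370 nM, and compound 1 `Nc1nc(Cl)c2ncn(Cc3ccc(CCl)cc3)c2n1` gives 44700 nM. Compound 2 and compound 3 are built from the same atoms joined differently; the difference between their two cores is not broken down here, and their two values lie within the scatter of one another. Compound 1 differs from compound 3 by a single change, (amino in place of chloro on an aromatic carbon), and that change produced a 6.5-fold higher number from compound 3 to compound 1 (0.81 log units; beyond the scatter).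

Compound 4 `Nc1nc(Cl)c2ncn(Cc3cccc(CCl)c3)c2n1` has not yet been measured. It differs from compound 2 by amino in place of chloro on an aromatic carbon, the same change as from compound 3 to compound 1, at a place described in the same words. Since the same change produced a 6.5-fold higher number from compound 3 to compound 1 (0.81 log units; beyond the scatter) in that earlier pair, compound 4 is expected to show a similar step, a 6.5-fold higher number from compound 2 to compound 4 (0.81 log units; beyond the scatter). In this assay compound 4 is therefore expected to give about 35000 nM, within a likely range from 15000 nM to 80000 nM. This expectation rests on one earlier pair only, so it remains uncertain.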

Compound 4, concentration for total growth inhibition: 19100 nM
Compound 4: middle estimate off by 1.8-fold (0.26 log units), on the high side; measured number inside the range.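

In this assay, amino in place of chloro on an aromatic carbon again weakens growth inhibition, this time with a 3.6-fold higher number from compound 2 to compound 4 (0.55 log units; beyond the scatter). Direction and size both carry over from one core to the other, as the two steps show when set side by side: the same change on two cores in this assay, a 6.5-fold higher number (0.81 log units; beyond the scatter) from compound 3 to compound 1 and a 3.6-fold higher number (0.55 log units; beyond the scatter) from compound 2 to compound 4, 1.8-fold (0.26 log units) apart, within the scatter of two such steps. For the compounds shown here, this is still only two pairs in one assay, so it supports carrying the change between these two closely related cores but does not show that it would hold on a more different core, and it gives no reason why the amino compounds are the weaker inhibitors.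

The compounds shown leave open how a methylamino or a methoxy group would fare in place of the chloro between two ring nitrogen atoms, since amino is the only replacement here. They also leave open whether the same step would appear on other cell lines, outside this assay.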